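Replacing pyrrolidin-1-yl with (methylamino)methyl: metabolic stability

The source may report more compounds than this note shows. Statements on the series, on what has been measured and on what is new or still open speak of the compounds shown alone.

Measured compounds:
Compound 1, `CCCCCOC(=O)N1CCN(C(=O)[C@H](CCC(=O)O)NC(=O)c2nc(-c3ccccc3)cc(N3CCC(COC)CC3)n2)CC1`, gives > 80%.
Compound 2, `CCCCCOC(=O)N1CCN(C(=O)[C@H](CCC(=O)O)NC(=O)c2cc(N3CCC(N4CCCC4)CC3)nc(-c3ccccc3)n2)CC1`, gives > 80%.

Both were tested in an ADME assay on microsomes from liver (Homo sapiens) for metabolic stability; on this read-out higher numbers stand for a more stable compound and lower numbers for a less stable compound. For compound 1 the value is a limit of the assay, not a number. For compound 2 the value is likewise a limit. Compound 2 thus stands at the limit, the point at which both values shown sit (the limit of > 80% in this assay, at which 2 of the 2 values shown sit). Compound 3, `CCCCCOC(=O)N1CCN(C(=O)[C@H](CCC(=O)O)NC(=O)c2cc(N3CCC(CNC)CC3)nc(-c3ccccc3)n2)CC1`, has not yet been measured. It differs from compound 2 in one place: (methylamino)methyl in place of pyrrolidin-1-yl on a saturated ring carbon. Going by the values given here, no pair of measured compounds here differs in exactly one place, so no measured step guides the expectation directly. With both known values at the limit, the step from compound 2 to compound 3 is expected to be small or none beyond the scatter, a number no higher from compound 2 to compound 3 (the limit leaves the size open). Compound 3 is therefore estimated at 80%, with a range from 60% to 95%.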

Compound 3, percent of the compound remaining: > 80%
Compound 3: a limit, no number; the forecaster's own chance of this, stated with the estimate: 55%; the middle value sits exactly at the limit.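

In this assay compound 3 gives > 80% as a limit of the assay and not a number. Going by these compounds alone, compound 2 also sits at a limit, so no step from compound 2 to compound 3 can be read: the limit of > 80% in this assay, at which 3 of the 3 values shown sit. The compounds shown leave open whether (methylamino)methyl in place of pyrrolidin-1-yl changes the result at all.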